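The source may hold more compounds than are shown below. What is called first, only, known or untested is meant among the compounds shown, and "the series" means these compounds.

Measured compounds:
Compound 1, `O=C1NC(=S)/C(=C/c2cccc(Cl)c2)S1`: in a functional assay on NCI-H292 cells (Homo sapiens) for cytotoxicity, read by MTT assay, with a stated time of 72 h, tested at 10 ug/mL (a higher number here means more inhibition of growth at the concentration tested, a lower number less inhibition of growth), compound 1 gives 30.9%.
Compound 2, `O=C1NC(=S)/C(=C/c2cccc(F)c2)S1`: in this assay compound 2 gives 26.8%.

For the measured compounds named here, compound 2 holds the lower of the two numbers so far; its nearest neighbour is compound 1, and the step of a number 4.1 percentage points lower from compound 1 to compound 2 (within the scatter) is within the scatter, so the two compounds cannot be ordered on these data.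

Compound 3, `O=C1NC(=S)/C(=C/c2cccc(Br)c2)S1`, is the next member: bromo in place of fluoro on an aromatic carbon. Going by the values given here, the only measured step that bears on this change is the exchange of one halogen for another at the same aromatic carbon, a number 4.1 percentage points lower from compound 1 to compound 2 (within the scatter), which stayed within the scatter. On that basis a further halogen exchange at the same place is expected to give no step beyond the scatter in this assay, in either direction; the expected step of a number 4.2 percentage points higher from compound 2 to compound 3 (within the scatter) is a small one. Compound 3 is therefore estimated at 31% in this assay, with a range from 20% to 42%, the spread mostly reflecting the scatter of single-concentration readings of this kind rather than any trend across the halogens.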

Compound 3, percent growth inhibition at one concentration: 42.4%
For compound 3 the middle estimate is 11.4 percentage points below the measured one, outside the stated range (above it).
By their numbers in this assay, from the lowest: compounds 2 and 1 (each within the scatter of the next); then compound 3.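

In this assay this aromatic carbon responds to the choice of halogen: the change to bromo gives a number 15.6 percentage points higher from compound 2 to compound 3 (beyond the scatter) and also a number 11.5 percentage points higher from compound 1 to compound 3 (beyond the scatter) in the step from chloro, whereas the exchange of chloro for fluoro alone gave no step beyond the scatter. Compound 3 therefore stands highest of the three, with compound 1 and compound 2 still unordered, so a halogen exchange at this place cannot be treated as uniformly silent, although the finding rests on a single bromo compound. No measured property is available to account for the separation of bromo from the other two halogens.

On these data alone, whether the higher number belongs to bromo alone or extends to other groups at the same aromatic carbon remains open, and iodo, methyl or methoxy there would help to separate these readings. Also open, as far as these compounds go, is how an amine or a carboxylic acid at this place would read in this assay and whether the bromo step would hold on repeated readings or at other concentrations.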